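Shared core series: ethylamino to methylamino at the amide

The source may report more compounds than this note shows. Statements on the series, on what has been measured and on what is new or still open speak of the compounds shown alone.

Three compounds of the series carry a number in an assay on the whole organism (plasma, strain Sprague-Dawley) for inhibition of Dipeptidyl peptidase 4 (Rattus norvegicus), with a stated time of 10 h, at a dose of 1 mg/kg by the oral route; on this read-out higher numbers stand for more inhibition at the one dose given (going by the name of the read-out) and lower numbers for less inhibition. In this assay compound 1 `N#C[C@@H]1CCCN1C(=O)[C@@H]1C[C@H](C(=O)N2CCOCC2)CN1` gives 44%, compound 2 `CCNC(=O)[C@@H]1CN[C@H](C(=O)N2CCC[C@H]2C#N)C1` gives 19%, and compound 3 `C[C@@H]1N[C@H](C(=O)N2CCC[C@H]2C#N)C[C@@H]1C(=O)N1CCCCC1` gives 81%. Compound 2 thus stands lowest of the three numbers; its nearest neighbour is compound 1 and its furthest is compound 3, and both gaps lie beyond the scatter. For the measured compounds named here, the one step measured between compounds that differ in a single place is a number 25 percentage points lower from compound 1 to compound 2 (beyond the scatter), where ethylamino replaces morpholin-4-yl on a carbonyl carbon.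

Compound 4 `CNC(=O)[C@@H]1CN[C@H](C(=O)N2CCC[C@H]2C#N)C1` has not yet been measured in this assay. Against compound 2 its change is hydrogen in place of methyl on a saturated chain carbon bound to an amide-type nitrogen; cut one bond further out, this reads ethylamino to methylamino, or ethylcarbamoyl to methylcarbamoyl. Going by the values given here, no measured step covers this change: the single step available exchanges the whole group on the carbonyl carbon rather than shortening its chain, so it offers no direction for the loss of one carbon at the amide nitrogen. The step expected from compound 2 to compound 4 is therefore none beyond the scatter, and the estimated outcome is a number 1 percentage points higher from compound 2 to compound 4 (within the scatter). Compound 4 is estimated at 20%, within a range from 5% to 40%.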

Compound 4, a percentage reported as inhibition, in the whole organism at one dose (the size of the read-out at that dose, not a potency): 28%
Beside the measured number, compound 4's estimate is 8 percentage points below it; low and high end bracket the measured number.
By their numbers in this assay, from the lowest: compounds 2 and 4 (each within the scatter of the next); then compound 1; then compound 3.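

In this assay, shortening the chain on the amide nitrogen from ethyl to methyl gives a number 9 percentage points higher from compound 2 to compound 4 (within the scatter) and so leaves the read-out within the scatter, which makes this the first measured sign that the one carbon on a saturated chain carbon bound to an amide-type nitrogen carries no readable weight at this dose. Replacing the whole group on the carbonyl carbon is a different kind of change, and methylamino in place of morpholin-4-yl gives a number 16 percentage points lower from compound 1 to compound 4 (beyond the scatter) and stays beyond the scatter, as ethylamino did in the earlier step, so the two short amides now agree in lying under the morpholin-4-yl amide of compound 1. Nothing at hand accounts for these numbers or separates exposure from enzyme inhibition in this whole-organism read-out.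

Open, on these data alone, is how far the amide nitrogen can be varied beyond ethyl and methyl: a longer chain such as propyl, the unsubstituted carboxamide with two hydrogens on the nitrogen, or a carboxylic acid in place of the amide would each extend this short run. Also open, as far as these compounds go, is whether the change from ethylamino to methylamino would stay within the scatter on a core bearing the ring methyl group of compound 3.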